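Hexyl in Place of Isopropyl on the Amide Carbonyl

The compounds below may be only part of what the source reports. "The series", "measured", "known", "first", "only" and "open" are said of these compounds alone.

Compounds measured so far:
compound 1, `O=C(O)CC/C=C\C[C@@H]1CN(Cc2ccccc2)C[C@@H]1c1ccccc1O`: 251 nM
compound 2, `CC(C)C(=O)N1C[C@@H](C/C=C\CCC(=O)O)[C@@H](c2ccccc2O)C1`: 200 nM

In a functional assay (Cavia porcellus) for antagonist activity at thromboxane A2 receptor (Homo sapiens) (on this read-out higher numbers stand for weaker binding and lower numbers for tighter binding), compound 1 gives 251 nM and compound 2 gives 200 nM. Among the measured compounds shown here, the one recorded step, a 1.3-fold lower number from compound 1 to compound 2 (0.10 log units; within the scatter), changes little, so compound 2 has the lower of the two numbers but cannot be separated from compound 1 in this assay.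

Compound 3, `CCCCCCC(=O)N1C[C@@H](C/C=C\CCC(=O)O)[C@@H](c2ccccc2O)C1`, has not been measured. It differs from compound 2 at a single place: hexyl in place of isopropyl on a carbonyl carbon whose other neighbours are an amide-type nitrogen in a ring. For the measured compounds named here, no measured step touches this change: the only step known exchanges the substituent on the ring nitrogen, not the chain on the carbonyl. The data therefore offer no direction, and the step of no change at the digits printed from compound 2 to compound 3 (within the scatter) is expected to stay within the usual scatter. Compound 3 is estimated at 200 nM, with a range from 70 nM to 600 nM, until a measurement exists.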

Compound 3, dissociation constant: 20 nM
Beside the measured number, compound 3's estimate is 10-fold (1.00 log units) above it; measured number outside the range, below it.
By their numbers in this assay, from the lowest: compound 3; then compounds 2 and 1 (each within the scatter of the next).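

In this assay the group on the carbonyl carbon proves to be a position where the number can move: hexyl in place of isopropyl gives a 10-fold lower number from compound 2 to compound 3 (1.00 log units; beyond the scatter), whereas the earlier exchange on the ring nitrogen could not separate compound 1 from compound 2. Hexylcarbonyl in place of benzyl on the ring nitrogen gives a 13-fold lower number from compound 1 to compound 3 (1.10 log units; beyond the scatter), so compound 3 stands apart from both earlier compounds, and the gain is tied to the hexyl chain rather than to the carbonyl alone. Nothing available explains why this chain lowers the number.

Only isopropyl and hexyl are shown on the carbonyl, so it remains open whether the number keeps falling with a butyl or an octyl chain, or whether a cyclohexyl ring would serve as well. As far as these compounds go, it is also open whether a hexyl group set directly on the ring nitrogen, without the carbonyl, would keep this value.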